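Amide substituent series: from cyclohexylamino to pyrrolidin-1-yl

The source may report more compounds than this note shows. Statements on the series, on what has been measured and on what is new or still open speak of the compounds shown alone.

Measured compounds:
compound 1 `COc1cc2c(cc1OC)C(CC(=O)NC(C)C)CC2` — 37%
compound 2 `CCCCNC(=O)CC1CCc2cc(OC)c(OC)cc21` — 24%
compound 3 `COc1cc2c(cc1OC)C(CC(=O)NC1CCCCC1)CC2` — 56%

In a functional assay on the whole organism (strain Wistar) for inhibition, with Rattus norvegicus as the target, read by paw edema, with stated times of 60 min and 2 h, at a dose of 100 mg/kg by the oral route (on this read-out higher numbers stand for more inhibition at the one dose given (going by the name of the read-out) and lower numbers for less inhibition), compound 3 gives the highest of the three numbers, with compound 1 nearest and compound 2 furthest. Compound 4 `COc1cc2c(cc1OC)C(CC(=O)N1CCCC1)CC2` is unmeasured; it carries pyrrolidin-1-yl in place of cyclohexylamino on a carbonyl carbon. The measured steps that bear on it are those reaching the cyclohexyl group: a number 19 percentage points higher from compound 1 to compound 3 (beyond the scatter) and a number 32 percentage points higher from compound 2 to compound 3 (beyond the scatter). Both show that changing the group on the amide nitrogen moves the read-out beyond the scatter, and that the smaller groups sit lower. For the measured compounds named here, no measured step removes the amide hydrogen, so that part of the change is unsupported by data. Compound 4 is expected to fall, with the step of a number 21 percentage points lower from compound 3 to compound 4 (beyond the scatter) estimated as modest. The estimate for compound 4 is 35%, ranging from 15% to 55%.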

Compound 4, a percentage reported as inhibition, in the whole organism at one dose (the size of the read-out at that dose, not a potency): 20%
For compound 4 the middle estimate is 15 percentage points above the measured one, within the range that was stated.
By their numbers in this assay, from the lowest: compounds 4 and 2 (each within the scatter of the next); then compound 1; then compound 3.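

In this assay, a ring on the carbonyl carbon does not by itself keep the read-out high: pyrrolidin-1-yl, with no hydrogen-bond donor, falls well short of cyclohexylamino (a number 36 percentage points lower from compound 3 to compound 4 (beyond the scatter)). Against the open-chain groups, the steps are (a number 17 percentage points lower from compound 1 to compound 4 (beyond the scatter)) and (a number 4 percentage points lower from compound 2 to compound 4 (within the scatter)), so pyrrolidin-1-yl gains nothing over butylamino. No available evidence accounts for these differences.

The step to compound 4 changes both the ring and the amide hydrogen, and these remain unseparated. Cyclopentylamino and piperidin-1-yl would be the groups to tell them apart.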